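Swapping a Cyanopyridine for a Chlorophenyl Ring

A few compounds are considered here, and "the series" means these few. Any claim that something is new, unique, unknown or untested is made for them only; others in the source may bear on it.

Measured compounds:
compound 1 `N#Cc1cccnc1N1CCN([C@@H]2CN[C@H](C(=O)N3CCSC3)C2)CC1`: 1.2 nM
compound 2 `COc1ccc(N2CCN([C@@H]3CN[C@H](C(=O)N4CCSC4)C3)CC2)cc1`: 16.9 nM
compound 3 `N#Cc1ccnc(N2CCN([C@@H]3CN[C@H](C(=O)N4CCSC4)C3)CC2)c1`: 1.9 nM

All three share one core and differ only in the aromatic group attached to an amine nitrogen in a ring. In an assay on a cell-free system (plasma) for inhibition of Dipeptidyl peptidase 4 (Rattus norvegicus), read by fluorescence (a higher number here means a weaker inhibitor, a lower number a stronger inhibitor), compound 3 gives 1.9 nM, the second highest of the three numbers. Its neighbour is close, as a 1.6-fold higher number from compound 1 to compound 3 (0.20 log units; within the scatter), whereas the remaining compound sits far off, as an 8.9-fold lower number from compound 2 to compound 3 (0.95 log units; beyond the scatter).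

Compound 4 `O=C([C@@H]1C[C@H](N2CCN(c3ccccc3Cl)CC2)CN1)N1CCSC1` has not yet been measured. Its change from compound 3 is 2-chlorophenyl in place of 4-cyanopyridin-2-yl on an amine nitrogen in a ring. Going by the values given here, two measured steps bear on this, the two in which the cyanopyridinyl ring was exchanged for an aromatic ring of carbon only: a 14-fold higher number from compound 1 to compound 2 (1.15 log units; beyond the scatter), and in the opposite direction an 8.9-fold lower number from compound 2 to compound 3 (0.95 log units; beyond the scatter). Both times the compound carrying the carbon-only ring had the higher number. Compound 4 likewise carries a carbon-only ring, so a higher number, modest to large, is expected. Compound 4 is estimated at 12 nM, with a likely range of 3 nM to 50 nM, meaning an expected 6.3-fold higher number from compound 3 to compound 4 (0.80 log units; beyond the scatter).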

Compound 4, half-maximal inhibitory concentration: 10.9 nM
For compound 4 the middle estimate is 1.1-fold (0.04 log units) above the measured one, within the range that was stated.
By their numbers in this assay, from the lowest: compounds 1 and 3 (each within the scatter of the next); then compounds 4 and 2 (each within the scatter of the next).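

With compound 4, the higher number for a carbon-only ring no longer rests on 4-methoxyphenyl alone: in this assay, 2-chlorophenyl also stands well apart from both cyanopyridinyl rings (a 5.7-fold higher number from compound 3 to compound 4 (0.76 log units; beyond the scatter); a 9.1-fold higher number from compound 1 to compound 4 (0.96 log units; beyond the scatter)). Going by these compounds alone, the two carbon-only rings carry different groups yet cannot be told apart (a 1.6-fold lower number from compound 2 to compound 4 (0.19 log units; within the scatter)), so across these four compounds the results fall into two tiers, with both cyanopyridinyl compounds lower than both carbon-only compounds and no compound going against this. The data shown offer no explanation for this split.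

Going by these compounds, the ring nitrogen and the nitrile always occur together in the lower tier, so it remains open which of them goes with the lower numbers. A plain pyridin-2-yl ring and a 4-cyanophenyl ring would separate the two.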